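The source may hold more compounds than are shown below. What is called first, only, known or untested is meant among the compounds shown, and "the series" means these compounds.

Measured so far:
compound 1 `N#CC1=C(N)OC(c2c[nH]c3ccccc23)=C(C#N)C1c1ccccc1F` – "not active" (no number reported)
compound 2 `N#CC1=C(N)OC(c2c[nH]c3ccccc23)=C(C#N)C1c1ccc(Br)cc1` – 22.7%
compound 3 `COc1ccc(C2C(C#N)=C(N)OC(c3c[nH]c4ccccc34)=C2C#N)cc1OC` – 28.1%

In a functional assay, tested at 400 ug/mL (a higher number here means a stronger effect of the compound at the concentration tested, a lower number a weaker effect), compound 1 is reported as "not active" (no number reported), without a number. Compound 2 gives 22.7% and compound 3 gives 28.1% in this assay. Among the measured compounds shown here, the one step between measured compounds is a number 5.4 percentage points higher from compound 2 to compound 3 (within the scatter). Compound 3 therefore holds the higher of the two numbers, but its gap to compound 2 lies within the scatter, so no order between the two can be read.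

Compound 4 `Cc1ccccc1C1C(C#N)=C(N)OC(c2c[nH]c3ccccc23)=C1C#N` is not yet measured. It differs from compound 3 as follows: 2-methylphenyl in place of 3,4-dimethoxyphenyl on a saturated ring carbon. For the measured compounds named here, the only measured step that bears on this change is the exchange of the group on the same saturated ring carbon, a number 5.4 percentage points higher from compound 2 to compound 3 (within the scatter), which was within the scatter. Compound 1, which also carries a different group at that position, gave no number. On these data, no step beyond the scatter is expected in this assay; the number for compound 4 is estimated at 22%, with a range from 5% to 35%, which means an expected step of a number 6.1 percentage points lower from compound 3 to compound 4 (within the scatter). The result of compound 1 leaves a clear chance that compound 4 is likewise reported without a number.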

Compound 4, a percentage reported as activity, at one concentration (the size of the read-out at that concentration, not a potency): 25.7%
Compound 4: the middle estimate sits 3.7 percentage points below what was measured; the range from low to high includes it.
By their numbers in this assay, from the lowest: compounds 2, 4 and 3 (each within the scatter of the next).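

In this assay, the exchange on the saturated ring carbon gives a number 2.4 percentage points lower from compound 3 to compound 4 (within the scatter) and a number 3 percentage points higher from compound 2 to compound 4 (within the scatter), so 3,4-dimethoxyphenyl, 4-bromophenyl and 2-methylphenyl cannot be told apart at this position, even though 2-methylphenyl brings 7 heavy atoms and 0 hydrogen-bond acceptors in place of the 10 heavy atoms and 2 hydrogen-bond acceptors of 3,4-dimethoxyphenyl. This flat pattern over the three numbered compounds has one exception: compound 4 gives a number with a substituted phenyl on this carbon, whereas compound 1 is reported as "not active" (no number reported), so a substituent on the phenyl ring does not by itself rule out a number. No supporting data are available to account for either the flat pattern or the exception.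

As far as these compounds go, what separates compound 1 from compound 4 remains open, as the two differ only in the group on this carbon and only one of them has a number. Also open, from the compounds shown here alone, is whether a phenyl ring carrying an amine or a carboxylic acid, or a longer alkyl chain in place of the ring, would move the read-out beyond the scatter.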